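A few compounds are considered here, and "the series" means these few. Any claim that something is new, unique, unknown or untested is made for them only; others in the source may bear on it.

Measured in a functional assay on MGC-803 cells (Homo sapiens) for antiproliferative activity, read by MTT assay, with a stated time of 72 h; on this read-out higher numbers stand for weaker inhibition and lower numbers for stronger inhibition:
compound 1 `COc1ccccc1/C=C/C(=O)c1ccc(OCC(=O)N[C@H]2CCOC2=O)cc1`: 39400 nM
compound 2 `O=C1OCC[C@@H]1NC(=S)SCCOc1ccccc1Cc1ccccc1`: 32300 nM
compound 3 `O=C(CNc1cccc(Cl)c1)N[C@H]1CCOC1=O`: > 64000 nM, a limit of the assay, not a number

Compound 1 holds the higher of the two numbers, but compound 2 sits within the scatter of it, so no order between the two can be read. For compound 3 only the limit is recorded, (the limit of > 64000 nM in this assay, at which 1 of the 3 values shown sits). Compound 4 `O=C(COc1ccc(C(=O)/C=C/c2ccccc2)cc1)N[C@H]1CCOC1=O` differs from compound 1 by hydrogen in place of methoxy on an aromatic carbon. Within the data shown here, no step between measured compounds is available for comparison, so no measured anchor fixes the size of this change. The step from compound 1 to compound 4 is expected to stay within the scatter, a 1.1-fold lower number from compound 1 to compound 4 (0.05 log units; within the scatter). Compound 4 is estimated at 35000 nM, with a range from 14000 nM to 80000 nM.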

Compound 4, half-maximal inhibitory concentration: > 64000 nM
Compound 4 gave a limit, no number; the forecaster's own chance of this, stated with the estimate: 20%; at least 1.8-fold (0.26 log units) between middle value and limit.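

In this assay, compound 4 gives only a limit of the assay, > 64000 nM, not a number. Going by these compounds, removing the methoxy group, the 2-methoxyphenyl to phenyl change, gives an at least 1.6-fold higher number from compound 1 to compound 4 (0.21 log units; that floor lies within the scatter), so this floor alone does not establish a real loss of activity at this position, and the true size of the step stays unknown. The limit now covers a larger share of the series: the limit of > 64000 nM in this assay, at which 2 of the 4 values shown sit.

Still open, on these data alone, is whether a hydroxyl, an ethoxy group or an amine on this aromatic carbon would give a measurable number.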